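The compounds below may be only part of what the source reports. "The series", "measured", "known", "first", "only" and "open" are said of these compounds alone.

Working notes on the series. Compound 1 `O=C(O)CN1Cc2ccc(NC(=O)CCCC3CCNCC3)cc2C1=O` and compound 2 `O=C(O)CCCN1Cc2ccc(NC(=O)CCCC3CCNCC3)cc2C1=O` share a core and differ only in the acid-bearing chain. In a functional assay on a cell-free system (Platelet, plasma, Homo sapiens) for inhibition (on this read-out higher numbers stand for weaker inhibition and lower numbers for stronger inhibition), compound 1 gives 66000 nM, and in this assay compound 2 gives 51000 nM; the two values lie within the usual scatter of each other, so compound 2 stands alongside compound 1 rather than apart from it. Among the measured compounds shown here, the single measured step, a 1.3-fold lower number from compound 1 to compound 2 (0.11 log units; within the scatter), is the only one that bears on the next move. Compound 3 `O=C(O)CCN1Cc2ccc(NC(=O)CCCC3CCNCC3)cc2C1=O` carries the change (carboxy in place of carboxymethyl on a saturated chain carbon, two bonds along the chain from an amide-type nitrogen in a ring), an intermediate chain length. Because a 1.3-fold lower number from compound 1 to compound 2 (0.11 log units; within the scatter) was within the scatter, no step beyond the scatter is expected in this assay for compound 3, and the expected step is a 1.1-fold higher number from compound 2 to compound 3 (0.04 log units; within the scatter). Compound 3 is estimated at 56000 nM, with a range from 30000 nM to 110000 nM.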

Compound 3, half-maximal inhibitory concentration: 5900 nM
Compound 3: the middle estimate sits 9.5-fold (0.98 log units) above what was measured; the measured number lies below the stated range.
By their numbers in this assay, from the lowest: compound 3; then compounds 2 and 1 (each within the scatter of the next).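

In this assay the length of the acid-bearing chain turns out to matter: an 8.6-fold lower number from compound 2 to compound 3 (0.94 log units; beyond the scatter) and an 11-fold lower number from compound 1 to compound 3 (1.05 log units; beyond the scatter) set the 2-carboxyethyl chain apart from both the carboxymethyl and 3-carboxypropyl chains. The response at this position is therefore not steady with chain length, which the pair compound 1 and compound 2 could not show. No available evidence accounts for this. Still open, as far as these compounds go, is whether the gain needs the carboxylic acid itself or would survive with a primary amide at the end of the chain. From the compounds shown here alone, a methyl branch on the 2-carboxyethyl chain also remains untested here.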